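Removing One Methyl From an Amine in a Biaryl Series

The compounds below may be only part of what the source reports. "The series", "measured", "known", "first", "only" and "open" are said of these compounds alone.

Among the measured compounds shown here, compound 2 `COc1ccccc1-c1cc(CN(C)C)ccc1OC` is one of two compounds measured in an assay on HEK293 cells for displacement of a labelled ligand from 5-hydroxytryptamine receptor 7 (Homo sapiens), read by scintillation counting, with a stated time of 1.5 h, in the absence of a further agent (on this read-out higher numbers stand for weaker inhibition and lower numbers for stronger inhibition), and of those two numbers it gives the higher one, 1020 nM. Compound 1 `CNCc1ccc(Cl)c(-c2ccccc2OC)c1` differs from compound 2 in two places; in this assay compound 1 gives 5.2 nM, by a wide margin the lower of the two. Compound 3 `CNCc1ccc(OC)c(-c2ccccc2OC)c1` has not yet been measured. It keeps the core of compound 2 and differs from it in a single change: hydrogen in place of methyl on an amine nitrogen, so that the dimethylamino group becomes a methylamino group. For the measured compounds named here, no measured pair shows this change on its own, so its effect is untested here; compound 1, the stronger binder, does carry the methylamino group, but it also differs from compound 2 elsewhere, so it is only a rough guide. The change is expected to lower the number beyond the scatter, giving a 10-fold lower number from compound 2 to compound 3 (1.01 log units; beyond the scatter). Compound 3 is estimated at 100 nM, with a likely range from 20 nM to 500 nM.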

Compound 3, inhibition constant: 648 nM
Estimate against measurement, compound 3: 6.5-fold (0.81 log units) below, and the stated range ends below it.
By their numbers in this assay, from the lowest: compound 1; then compounds 3 and 2 (each within the scatter of the next).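

In this assay hydrogen in place of methyl on an amine nitrogen, turning dimethylamino into methylamino, gives a 1.6-fold lower number from compound 2 to compound 3 (0.20 log units; within the scatter) and so, on this core, the change alone barely registers. Methoxy in place of chloro on an aromatic carbon behaves very differently, giving a 120-fold higher number from compound 1 to compound 3 (2.10 log units; beyond the scatter) and making this aromatic carbon, not the amine nitrogen, the place where a single change is shown to move the number far beyond the scatter. No measurement shown here explains either result.

Going by these compounds, it remains open whether the amine change would stay as small on the chloro-bearing core of compound 1. On these data alone, it is also open how a bromo group or a trifluoromethyl group on that aromatic carbon would compare, or how a primary amine would compare at the nitrogen.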